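This account rests on a few compounds, and the source may have more. Where it says the series, first, only, none or still open, it means among the compounds named here.

Among the compounds with values here, compound 2 `O=C(CCCCC1CCSS1)NCc1cn(CCCOc2ccc3cc(C(=O)O)c(=O)oc3c2)nn1` holds the higher of the two numbers known so far: in a functional assay on PC-12 cells (Rattus norvegicus) for cytotoxicity, read by MTT assay, with stated times of 3 h and 2 h, tested at 1 uM (a higher number here means a stronger effect of the compound at the concentration tested, a lower number a weaker effect), compound 2 gives 52.1%, while compound 1 `O=C(CCCCC1CCSS1)NCc1cn(CCCOc2ccc3ccc(=O)oc3c2)nn1` gives 37.2%. Within the data shown here, the single measured step, a number 14.9 percentage points higher from compound 1 to compound 2 (beyond the scatter), came with carboxy in place of hydrogen on an aromatic carbon. Compound 3 `COc1ccc(-c2cc3ccc(OCCCn4cc(CNC(=O)CCCCC5CCSS5)nn4)cc3oc2=O)cc1` differs from compound 2 by 4-methoxyphenyl in place of carboxy on an aromatic carbon. Among the measured compounds shown here, no measured step removes a carboxy or brings in a 4-methoxyphenyl, so the only bearing is that the carboxy of compound 2 is taken away again. A small downward step a number 10.1 percentage points lower from compound 2 to compound 3 (beyond the scatter) is therefore expected. Compound 3 is estimated at 42%, between 25% and 60%.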

Compound 3, a percentage reported as activity, at one concentration (the size of the read-out at that concentration, not a potency): 47.4%
For compound 3 the middle estimate is 5.4 percentage points below the measured one, and the stated range covers the measured number.
By their numbers in this assay, from the lowest: compound 1; then compounds 3 and 2 (each within the scatter of the next).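

With 4-methoxyphenyl in place of hydrogen on this aromatic carbon, this assay shows a number 10.2 percentage points higher from compound 1 to compound 3 (beyond the scatter), so the gain over hydrogen is not tied to carboxy alone. With 4-methoxyphenyl in place of carboxy, the step is a number 4.7 percentage points lower from compound 2 to compound 3 (within the scatter), so the two groups cannot be told apart here. Nothing available explains why these two different groups behave alike. Still open, on these data alone, is whether an unsubstituted phenyl, a methyl or an amine at this carbon would also stand apart from hydrogen. Also open, as far as these compounds go, is whether the methoxy contributes anything to the number.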